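The source may report more compounds than this note shows. Statements on the series, on what has been measured and on what is new or still open speak of the compounds shown alone.

Measured so far:
- compound 1, `COc1ccc(-c2cc(C(=O)/C=C/c3cc(OC)c(OC)c(OC)c3)nc3cc(-c4ccccc4)nn23)cc1OC`: 14700 nM
- compound 2, `COc1ccc(C(=O)/C=C/c2cc(-c3ccc(OC)c(OC)c3)n3nc(-c4ccccc4)cc3n2)cc1`: 14600 nM
- compound 3, `COc1cc(-c2cc(C(=O)/C=C/c3ccc(C)cc3)nc3cc(-c4ccccc4)nn23)cc(OC)c1OC`: 21900 nM

All three were tested in a functional assay on DU-145 cells (Homo sapiens) for antiproliferative activity, read by MTT assay, with a stated time of 24 h; on this read-out lower numbers stand for stronger inhibition and higher numbers for weaker inhibition. Compound 2 gives the lowest number of the three, but its gap to compound 1 and its gap to compound 3 both lie within the usual scatter, so no ranking among them can be drawn. Compound 4, `COc1ccc(-c2cc(/C=C/C(=O)c3ccc(C)cc3)nc3cc(-c4ccccc4)nn23)cc1OC`, has not been measured. It differs from compound 2 by methyl in place of methoxy on an aromatic carbon. Going by the values given here, no measured pair isolates this change, so the data give no direct guide to its size. With the three values standing so close together, the step in this assay is expected to be small, if anything toward a slightly higher number. Compound 4 is estimated at 18000 nM, with a range from 9000 nM to 36000 nM, meaning an expected step of a 1.2-fold higher number from compound 2 to compound 4 (0.09 log units; within the scatter).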

Compound 4, half-maximal inhibitory concentration: 26800 nM
For compound 4 the middle estimate is 1.5-fold (0.17 log units) below the measured one, within the range that was stated.
By their numbers in this assay, from the lowest: compounds 2, 1, 3 and 4 (each within the scatter of the next).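

In this assay, going by these compounds alone, the pair gives the first reading of a single change, methyl in place of methoxy on an aromatic carbon, with a 1.8-fold higher number from compound 2 to compound 4 (0.26 log units; within the scatter) and thus no separation of 4-methylphenyl from 4-methoxyphenyl on this carbonyl. At this position the swap therefore has no effect that can be told from the usual scatter. Nothing at hand bears on the reason for this result. Going by these compounds, whether an amine, a carboxylic acid or a longer chain at this position would shift the number beyond the scatter stays open.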